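Ester Chain in Place of Phenyl: Expected Cytotoxicity

This account rests on a few compounds, and the source may have more. Where it says the series, first, only, none or still open, it means among the compounds named here.

Compound 1 `Cc1cn([C@@H]2O[C@H](CO[Si](C)(C)C(C)(C)C)[C@@]3(OS(=O)(=O)C=C3NC(=O)NC(=O)c3ccccc3)[C@H]2O)c(=O)n(C)c1=O` gives > 100000 nM in an ADME assay on HEL cells (Homo sapiens) for cytotoxicity, with a stated time of 3 days (on this read-out higher numbers stand for lower toxicity in this test and lower numbers for higher toxicity in this test), which is a limit of the assay and not a number.
Compound 2 `Cc1cn([C@@H]2O[C@H](CO[Si](C)(C)C(C)(C)C)[C@@]3(OS(=O)(=O)C=C3NC(=O)Nc3ccccc3)[C@H]2O[Si](C)(C)C(C)(C)C)c(=O)n(C)c1=O` gives 1400 nM in this assay.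
Compound 3 `Cc1cn([C@@H]2O[C@H](CO[Si](C)(C)C(C)(C)C)[C@@]3(OS(=O)(=O)C=C3NC(=O)N(C(=O)Nc3ccccc3)c3ccccc3)[C@H]2O[Si](C)(C)C(C)(C)C)c(=O)n(C)c1=O` gives 46000 nM in this assay.

In this assay compound 2 has the lowest of the two numbers, meaning the strongest cytotoxicity seen. For the measured compounds named here, the only measured step, a 33-fold higher number from compound 2 to compound 3 (1.52 log units; beyond the scatter), came from phenylcarbamoyl in place of hydrogen on an amide-type nitrogen.

Compound 4 `CCOC(=O)CNC(=O)NC1=CS(=O)(=O)O[C@@]12[C@@H](CO[Si](C)(C)C(C)(C)C)O[C@@H](n1cc(C)c(=O)n(C)c1=O)[C@@H]2O[Si](C)(C)C(C)(C)C` differs from compound 2 by (ethoxycarbonyl)methyl in place of phenyl on an amide-type nitrogen. Going by the values given here, no measured step swaps phenyl for another group at that nitrogen, so the large step just named bears only loosely on it; a smaller move toward a higher number, that is less toxicity, is expected, a 3.6-fold higher number from compound 2 to compound 4 (0.55 log units; beyond the scatter). Compound 4 is therefore estimated at 5000 nM, between 1500 nM and 30000 nM.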

Compound 4, minimum cytotoxic concentration: 16000 nM
The estimate for compound 4 lay 3.2-fold (0.51 log units) below the measured number; the measured number falls inside the stated range.
By their numbers in this assay, from the lowest: compound 2; then compound 4; then compound 3. At a limit, above all of these: compound 1.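

Swapping phenyl for (ethoxycarbonyl)methyl on this amide-type nitrogen in this assay gives an 11-fold higher number from compound 2 to compound 4 (1.06 log units; beyond the scatter) and so lowers toxicity in this test. The six-membered aromatic ring at this place is therefore not required for a measurable number, and a chain with no ring gives less toxicity here. No measurement shown accounts for this change.

The step removes the ring and brings in the ester together, so their shares stay unseparated. A plain butyl chain or the free carboxylic acid on this nitrogen would help to tell them apart.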